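Sulfonyl replacing sulfanyl, with a longer chain, on the core

The source may hold more compounds than are shown below. What is called first, only, known or untested is meant among the compounds shown, and "the series" means these compounds.

Compound 1 `CCCSc1nnc(COc2cc(C)c3c(C)cc(=O)oc3c2)o1` carries a propylsulfanyl group on the shared core. In a functional assay on MDA-MB-231 cells (Homo sapiens) for antiproliferative activity, read by MTT assay, with a stated time of 24 h (a lower number here means a stronger inhibitor, a higher number a weaker inhibitor), compound 1 gives only the limit > 100000 nM. Compound 2 `CCCCCSc1nnc(COc2cc(C)c3c(C)cc(=O)oc3c2)o1` lengthens that chain. In this assay compound 2 likewise gives only the limit > 100000 nM. The step that the two limits leave unreadable from compound 1 to compound 2 is therefore unreadable. Compound 3 `CCCS(=O)(=O)c1nnc(COc2cc(C)c3c(C)cc(=O)oc3c2)o1` bears propylsulfonyl instead, and in this assay compound 3 reaches 7070 nM. The steps of an at least 14-fold lower number from compound 1 to compound 3 (1.15 log units; beyond the scatter) and an at least 14-fold lower number from compound 2 to compound 3 (1.15 log units; beyond the scatter) are both large, each measured against (the limit of > 100000 nM in this assay, at which 2 of the 3 values shown sit). Compound 4 `CCCCCCS(=O)(=O)c1nnc(COc2cc(C)c3c(C)cc(=O)oc3c2)o1` is not yet measured; it differs from compound 1 by hexylsulfonyl in place of propylsulfanyl on an aromatic carbon. The sulfonyl change bears directly on this step, while chain lengthening left no readable size. For compound 4 the expected step is an at least 14-fold lower number from compound 1 to compound 4 (1.15 log units; beyond the scatter). The estimate for compound 4 is 7000 nM, with a range from 2000 nM to 30000 nM.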

Compound 4, half-maximal inhibitory concentration: > 100000 nM
Compound 4: only a limit was reported (the forecaster's own chance of this, stated with the estimate: 15%); at least 14-fold (1.15 log units) between middle value and limit.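

In this assay the sulfonyl group alone does not secure a readable value at this position: hexylsulfonyl in place of propylsulfonyl gives an at least 14-fold higher number from compound 3 to compound 4 (1.15 log units; beyond the scatter) and so removes what compound 3 had gained. Chain length therefore matters on the sulfonyl series, whereas on the sulfanyl pair it could not be seen. The steps to compound 4 from compound 1 and from compound 2 cannot be read, since both ends of each are limits: the limit of > 100000 nM in this assay, at which 3 of the 4 values shown sit.

Open, from the compounds shown here alone, is how the value runs with a shorter ethylsulfonyl chain or with butylsulfonyl and pentylsulfonyl chains. Also open, going by these compounds, is whether an amine or a carboxylic acid at the end of the hexylsulfonyl chain would restore a measurable value.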